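Adding a Second Methoxy to a Sulfonate Ester Series

The source may hold more compounds than are shown below. What is called first, only, known or untested is meant among the compounds shown, and "the series" means these compounds.

Compound 1 `COc1ccc(OS(=O)(=O)c2ccc(N3CCN(C)C3=O)cc2)cc1OC` and compound 2 `COc1cc(OS(=O)(=O)c2ccc(N3CCN(C)C3=O)cc2)cc(OC)c1OC` share one core, and compound 3 `CCCN1CCN(c2ccc(S(=O)(=O)Oc3cccc(OC)c3)cc2)C1=O` and compound 4 `CCCN1CCN(c2ccc(S(=O)(=O)Oc3ccc(OC)c(OC)c3)cc2)C1=O` share another; the difference between the two cores is not broken down here. In a functional assay on HT-29 cells (Homo sapiens) for antiproliferative activity, read by sulforhodamine B assay, with a stated time of 48 h (on this read-out higher numbers stand for weaker inhibition and lower numbers for stronger inhibition), compound 1 gives 12000 nM, compound 2 gives 62 nM, and compound 3 gives 25000 nM. The change methoxy in place of hydrogen on an aromatic carbon brought a 190-fold lower number from compound 1 to compound 2 (2.29 log units; beyond the scatter). The same kind of change, (methoxy in place of hydrogen on an aromatic carbon), carries compound 3 into compound 4, which is not yet measured; around the place, however, the entering methoxy in compound 2 sits meta to a large group and meta to a methoxy group, whereas in compound 4 it sits para to a large group, so the two places are not the same. The expectation for compound 4 rests on the gain seen in a 190-fold lower number from compound 1 to compound 2 (2.29 log units; beyond the scatter), tempered because compound 1, which already holds two methoxy groups, gives 12000 nM. For compound 4 a step of a 2.5-fold lower number from compound 3 to compound 4 (0.40 log units; beyond the scatter) is therefore expected, and its value in this assay is estimated at 10000 nM, between 3000 nM and 30000 nM.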

Compound 4, half-maximal inhibitory concentration: 14000 nM
The estimate for compound 4 lay 1.4-fold (0.15 log units) below the measured number; measured number inside the range.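

Methoxy in place of hydrogen on an aromatic carbon did not carry its large gain from one core to the other in this assay: the same change on two cores in this assay, a 190-fold lower number (2.29 log units; beyond the scatter) from compound 1 to compound 2 and a 1.8-fold lower number (0.25 log units; within the scatter) from compound 3 to compound 4, 110-fold (2.03 log units) apart, beyond the scatter of two such steps. On the core of compound 3 the change gave a 1.8-fold lower number from compound 3 to compound 4 (0.25 log units; within the scatter), and ethyl in place of hydrogen on the saturated chain carbon, the step that links the two cores, gave a 1.2-fold higher number from compound 1 to compound 4 (0.07 log units; within the scatter). Among the compounds shown here, this does not show that the core alone sets the size of the step, since the entering methoxy in compound 4 sits ortho to a methoxy group and para to a large group, a different place from the one it takes in compound 2.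

The compounds shown leave open whether a methoxy entering at the place it takes in compound 2 would bring a similar gain on the core of compound 3. They also leave open whether a hydroxy group or an amine at that place would hold the value of compound 2, 62 nM.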